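This account rests on a few compounds, and the source may have more. Where it says the series, first, only, none or still open, it means among the compounds named here.

In a functional assay on A549 cells (Homo sapiens) for antiproliferative activity, read by MTT assay, with a stated time of 24 h (a higher number here means a weaker inhibitor, a lower number a stronger inhibitor), compound 1 (`O=C(NNc1ccccc1Cl)c1ccc(NS(=O)(=O)c2cnc(O)nc2O)cc1`) gives 3340 nM. Compound 2 (`O=C(NNc1ccc(F)cc1)c1ccc(NS(=O)(=O)c2cnc(O)nc2O)cc1`) gives > 20000 nM, which is a limit. Compound 3 (`Cc1cccc(NNC(=O)c2cccc(NS(=O)(=O)c3cnc(O)nc3O)c2)c1`) gives > 20000 nM, also a limit and not a number. This is the limit of > 20000 nM in this assay, at which 2 of the 3 values shown sit. Compound 4 (`O=C(NNC(=O)c1ccccc1Cl)c1cccc(NS(=O)(=O)c2cnc(O)nc2O)c1`) differs from compound 3 as follows: (2-chlorophenyl)carbonyl in place of 3-methylphenyl on an amine nitrogen, with (2-chlorophenyl)carbonyl in place of 3-methylphenyl on an amine nitrogen. Among the measured compounds shown here, no measured step makes this exact change. The nearest is an at least 5.9-fold higher number from compound 1 to compound 2 (0.77 log units; beyond the scatter), which is beyond the scatter and involves a change on an amine nitrogen, so a change there can matter. A modest move towards a lower number is expected, stated as an at least 1.3-fold lower number from compound 3 to compound 4 (0.12 log units; that floor lies within the scatter). The estimate for compound 4 is 15000 nM, with an expected range of 5000 nM to 30000 nM.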

Compound 4, half-maximal inhibitory concentration: 3740 nM
Compound 4: middle estimate off by 4.0-fold (0.60 log units), on the high side, outside the stated range (below it).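

In this assay, the amine nitrogen proves to be a place where the number can fall as well as rise: (2-chlorophenyl)carbonyl in place of 3-methylphenyl gives an at least 5.3-fold lower number from compound 3 to compound 4 (0.72 log units; beyond the scatter). The earlier step at an amine nitrogen went only upwards, with an at least 5.9-fold higher number from compound 1 to compound 2 (0.77 log units; beyond the scatter). The new step gives only a floor, as compound 3 stands at a limit and not a number: the limit of > 20000 nM in this assay, at which 2 of the 4 values shown sit.

The compounds shown do not separate the part played by the carbonyl from that of the chlorine. As far as these compounds go, how an acetyl group on this nitrogen would read also remains open.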